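Antagonists of a bitter taste receptor

A few compounds are considered here, and "the series" means these few. Any claim that something is new, unique, unknown or untested is made for them only; others in the source may bear on it.

Measured compounds:
compound 1, `Cc1noc(C)c1Cn1cc(N2CCN(Cc3ccccc3)C2=O)cn1`, 1000 nM
compound 2, `Cc1noc(C)c1Cn1cc(N2C(=O)CN(Cc3ccccc3)C2=O)cn1`, 200 nM

Two compounds share a core and differ in the ring that carries the benzyl group. In a functional assay on cells for antagonist activity at taste receptor type 2 member 8 (Homo sapiens), read by FLIPR and calcium flux, with a stated time of 100 s (on this read-out higher numbers stand for weaker inhibition and lower numbers for stronger inhibition), compound 1 gives 1000 nM, while in this assay compound 2 gives 200 nM. Compound 2 thus stands at the lowest number of the two, and the gap to compound 1 lies beyond the scatter of this kind of measurement.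

The next compound, compound 3, is `Cc1noc(C)c1Cn1cc(N2C(=O)CN(CC3CCCO3)C2=O)cn1`. It keeps the core of compound 2 and carries the change (oxolan-2-yl in place of phenyl on a saturated chain carbon bound to an amide-type nitrogen in a ring). Whether an oxolan-2-yl ring can stand in for phenyl at this place is not shown by any pair already measured. The step from compound 2 to compound 3 in this assay is expected to go toward a higher number, of modest size, and is estimated as a 3.0-fold higher number from compound 2 to compound 3 (0.48 log units; beyond the scatter). Compound 3 is therefore expected to give 600 nM, within a range from 200 nM to 2500 nM.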

Compound 3, half-maximal inhibitory concentration: 1000 nM
Estimate against measurement, compound 3: 1.7-fold (0.22 log units) below; the range from low to high includes it.
By their numbers in this assay, from the lowest: compound 2; then compounds 1 and 3 (each within the scatter of the next).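

In this assay, placing oxolan-2-yl in place of phenyl on a saturated chain carbon bound to an amide-type nitrogen in a ring gives a 5.0-fold higher number from compound 2 to compound 3 (0.70 log units; beyond the scatter), so the number at this place responds to what the chain carries. The phenyl group therefore cannot be exchanged for this non-aromatic ring with its one hydrogen-bond acceptor without a change beyond the scatter, although compound 3 still gives a measured value of 1000 nM in this assay. Nothing measured here accounts for the step.

This single pair changes the aromatic ring and the ring oxygen together and cannot separate the two. From the compounds shown here alone, whether a cyclohexyl ring, a pyridine ring or a longer chain ending in phenyl would hold the value of compound 2 at this place remains open.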